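Replacing 3-bromophenyl with 4-chlorophenyl on a shared core

The source may report more compounds than this note shows. Statements on the series, on what has been measured and on what is new or still open speak of the compounds shown alone.

Among the compounds with values here, only two compounds have numbers so far in a functional assay on CNE-2 cells (Homo sapiens) for cytotoxicity, read by sulforhodamine B assay, with a stated time of 48 h; on this read-out higher numbers stand for weaker inhibition and lower numbers for stronger inhibition. There, compound 1 (`O=C(/C=C/c1cccc(Br)c1)c1cccc(-c2cccc(F)c2)c1`) gives 6550 nM and compound 2 (`COc1ccc(/C=C/C(=O)c2ccc(N)c(-c3ccc(F)cc3)c2)cc1OC`) gives 3510 nM. These two values lie within the usual scatter of each other, so compound 1 cannot be told apart from compound 2 on these numbers. Compound 3 (`O=C(/C=C/c1ccc(Cl)cc1)c1cccc(-c2cccc(F)c2)c1`) has not yet been measured. It keeps the core of compound 1 and carries 4-chlorophenyl in place of 3-bromophenyl on a double-bonded chain carbon bound to a double-bonded chain carbon. Within the data shown here, no measured pair of compounds differing in one place is available as a guide, so the expectation rests on compound 1 at 6550 nM. The expected step in this assay is a 1.3-fold lower number from compound 1 to compound 3 (0.12 log units; within the scatter), a size estimated to stay within the scatter. For compound 3 the estimated value is 5000 nM, with an expected range from 2000 nM to 12000 nM.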

Compound 3, half-maximal inhibitory concentration: 9060 nM
The estimate for compound 3 lay 1.8-fold (0.26 log units) below the measured number, within the range that was stated.
By their numbers in this assay, from the lowest: compounds 2, 1 and 3 (each within the scatter of the next, the first and the last beyond it).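

In this assay, the first pair differing in one place gives a 1.4-fold higher number from compound 1 to compound 3 (0.14 log units; within the scatter) and so the two compounds cannot be told apart on the shared core. At this position, on a double-bonded chain carbon bound to a double-bonded chain carbon, 3-bromophenyl and 4-chlorophenyl therefore read alike, although the exchange alters both the halogen and the number in the group's name. Nothing available explains this result.

The compounds shown leave open whether 3-chlorophenyl or 4-bromophenyl, each altering only one of those two features, would also read alike. They also leave open whether a more different group on this ring, such as an amine or a carboxylic acid, would move the number beyond the scatter.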